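Swapping a methyl for oxolan-3-yl

A few compounds are considered here, and "the series" means these few. Any claim that something is new, unique, unknown or untested is made for them only; others in the source may bear on it.

Measured in an ADME assay on microsomes from liver (Homo sapiens) for pharmacokinetics; on this read-out lower numbers stand for slow clearance and higher numbers for fast clearance:
- Compound 1 `Cc1c(Nc2nc(N)c3c(C#N)c(N4CCC[C@H]4C)n(C)c3n2)cnn1C`: 41.7 mL/min/kg
- Compound 2 `Cc1nn(C2COC2)cc1Nc1nc(N)c2c(C#N)c(N3CCC[C@H]3C)n(C)c2n1`: 46.7 mL/min/kg

Going by the values given here, only these two compounds have numbers so far, and their values lie within the scatter of each other, so compound 1 stands level with its only neighbour. Compound 3 `Cc1c(Nc2nc(N)c3c(C#N)c(N4CCC[C@H]4C)n(C)c3n2)cnn1[C@H]1CCOC1` keeps the core of compound 1 but changes one group: oxolan-3-yl in place of methyl on an aromatic nitrogen. In words, oxolan-3-yl sits in place of methyl on an aromatic nitrogen.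

Among the compounds with values here, one measured step bears on this: a 1.1-fold higher number from compound 1 to compound 2 (0.05 log units; within the scatter). That step also brings in a ring holding oxygen, the oxetan-3-yl group, and it stays within the scatter. No step beyond the scatter is therefore expected in this assay, though a single step is thin support and the range stays wide. The expected change is a 1.2-fold higher number from compound 1 to compound 3 (0.06 log units; within the scatter). Compound 3 is estimated at 48 mL/min/kg, with an expected range of 28 mL/min/kg to 82 mL/min/kg.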

Compound 3, clearance: 23.3 mL/min/kg
Compound 3: the middle estimate sits 2.1-fold (0.31 log units) above what was measured; measured number outside the range, below it.
By their numbers in this assay, from the lowest: compounds 3, 1 and 2 (each within the scatter of the next).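

In this assay, oxolan-3-yl in place of methyl on the aromatic nitrogen gives a 1.8-fold lower number from compound 1 to compound 3 (0.25 log units; within the scatter). Compound 3 is the first case shown in which only the group on that nitrogen changes, while the rest of compound 1 stays as it is. Going from 1 heavy atom to 5 heavy atoms, with a non-aromatic ring, a hydrogen-bond acceptor and a defined stereocentre, therefore produces no step beyond the scatter at this position.

Still open, from the compounds shown here alone, is how this read-out would respond to the opposite stereoisomer of oxolan-3-yl, or to an amine, a carboxylic acid or a longer carbon chain on the same nitrogen. Nothing available here explains the result for compound 3.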